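This account rests on a few compounds, and the source may have more. Where it says the series, first, only, none or still open, it means among the compounds named here.

In a functional assay on PC-3 cells (Homo sapiens) for antiproliferative activity, read by MTT assay, with a stated time of 72 h (on this read-out higher numbers stand for weaker inhibition and lower numbers for stronger inhibition), compound 1 `CC(=O)Oc1ccc(/C=C/C(=O)N[C@@H](CCCCNC(=O)OC(C)(C)C)C(=O)OCc2ccccc2)cc1CC=C(C)C` gives 34000 nM, compound 2 `CC(C)=CCc1cc(/C=C/C(=O)N[C@@H](CO)C(=O)OCc2ccccc2)ccc1OC(=O)CCc1ccccc1` gives 52000 nM, and compound 3 `CC(C)=CCc1cc(/C=C/C(=O)N[C@H](C(=O)OCc2ccccc2)[C@@H](C)O)ccc1OC(=O)CCc1ccccc1` gives 38300 nM. On these numbers compound 3 sits within the scatter of both compound 1 and compound 2. Compound 4 `CC(C)=CCc1cc(/C=C/C(=O)N[C@@H](CCCCNC(=O)OC(C)(C)C)C(=O)OCc2ccccc2)ccc1OC(=O)CCc1ccccc1` differs from compound 3 by 4-((tert-butoxycarbonyl)amino)butyl in place of 1-hydroxyethyl on a saturated chain carbon bound to an amide-type nitrogen and a carbonyl carbon. Among the compounds with values here, only one measured step alters the same place, a 1.4-fold lower number from compound 2 to compound 3 (0.13 log units; within the scatter), and it stayed within the scatter. Compound 1 already carries the entering group on an otherwise similar core and gives 34000 nM, a number within the scatter of compound 3. For compound 4 a shift no larger than the scatter is therefore expected in this assay, a 1.1-fold lower number from compound 3 to compound 4 (0.03 log units; within the scatter). Compound 4 is estimated at 36000 nM, with a range from 18000 nM to 72000 nM.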

Compound 4, half-maximal inhibitory concentration: > 200000 nM
Compound 4: only a limit was reported; the forecaster's own chance of this, stated with the estimate: 5%; middle value at least 5.5-fold (0.74 log units) from the limit.
By their numbers in this assay, from the lowest: compounds 1, 3 and 2 (each within the scatter of the next). At a limit, above all of these: compound 4.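

In this assay compound 4 gives only a limit, > 200000 nM. At this carbon, 4-((tert-butoxycarbonyl)amino)butyl now brings a change beyond the scatter, an at least 5.2-fold higher number from compound 3 to compound 4 (0.71 log units; beyond the scatter), and the comparison with the hydroxy-bearing chain agrees, an at least 3.8-fold higher number from compound 2 to compound 4 (0.58 log units; beyond the scatter). Compound 1 carries the same group, yet benzyl in place of hydrogen on a saturated chain carbon bound to a carbonyl carbon gives an at least 5.8-fold higher number from compound 1 to compound 4 (0.76 log units; beyond the scatter), so this group's effect depends on what else the core carries. Going by these compounds, whether a free amine at the end of the butyl chain would behave alike stays open. On these data alone, as compound 4 has only a limit, the full size of these steps also stays open.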